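Series notes on compounds 1 to 3

This account rests on a few compounds, and the source may have more. Where it says the series, first, only, none or still open, it means among the compounds named here.

compound 1 `COc1ccc([C@H]2CC(=O)N(c3ccccc3C(F)(F)F)C2)cc1OC1CCCC1`: > 10000 nM
compound 2 `COc1ccc([C@H]2CC(=O)N(c3cccc([S+](C)[O-])c3)C2)cc1OC1CCCC1`: > 10000 nM

In a functional assay on HEK293 cells (Homo sapiens) for cytotoxicity (a lower number here means that less compound is tolerated, a higher number that more compound is tolerated), compound 1 gives > 10000 nM, which is a limit of the assay and not a number. In this assay compound 2 gives > 10000 nM, again a limit. The step that the two limits leave unreadable from compound 1 to compound 2 is therefore not readable in size or direction. Compound 2 stands at the limit of > 10000 nM in this assay, at which 2 of the 2 values shown sit; nothing shown separates it from compound 1.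

Compound 3 `COc1ccc([C@H]2CC(=O)N(c3cccc(NS(=O)(=O)c4ccccc4Br)c3)C2)cc1OC1CCCC1` differs from compound 2 by a group of 11 heavy atoms (6 carbon, 1 nitrogen, 2 oxygen, 1 sulfur, 1 bromine; one six-membered aromatic ring of carbon only) in place of a group of 3 heavy atoms (1 carbon, 1 oxygen, 1 sulfur; no ring), on an aromatic carbon.

Among the compounds with values here, the only measured step, a step that the two limits leave unreadable from compound 1 to compound 2, does not bear readably on this change, so no size or direction can be derived from it. The expectation rests on compound 2 alone, whose value is a limit in this assay. Compound 3 is expected to give 10000 nM, with a range from 3000 nM to 30000 nM. The step this means, a number no higher from compound 2 to compound 3 (the limit leaves the size open), is expected to be none beyond the scatter, with a limit again the likeliest report.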

Compound 3, half-maximal cytotoxic concentration: > 10000 nM
Compound 3 was reported as a limit; the forecaster's own chance of this, stated with the estimate: 65%; the middle value lies on the limit itself.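

In this assay, within the data shown here, compound 3 gives > 10000 nM, a limit and not a number, so no step from compound 2 to compound 3 can be read. The compounds shown leave open whether any of these groups on the shared core changes the tolerated concentration: the limit of > 10000 nM in this assay, at which 3 of the 3 values shown sit.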